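The source may report more compounds than this note shows. Statements on the series, on what has been measured and on what is new or still open speak of the compounds shown alone.

Of the compounds shown here, three sharing one core have been measured in a functional assay on A549 cells (Homo sapiens) for inhibition, read by MTT assay, with a stated time of 24 h, tested at 5 uM; on this read-out lower numbers stand for less inhibition of growth and higher numbers for more inhibition of growth at the one concentration tested. Compound 1 `N#Cc1ccc(-c2cnc3[nH]cc(-c4nnc(-c5ccc(Cl)cc5)o4)c(=O)c3c2)cc1` gives 7.6%, compound 2 `Cc1ccc(-c2nnc(-c3c[nH]c4ncc(-c5ccc(S(C)(=O)=O)cc5)cc4c3=O)o2)cc1` gives 6.69%, and compound 3 `CS(=O)(=O)c1ccc(-c2cnc3[nH]cc(-c4nnc(-c5ccncc5)o4)c(=O)c3c2)cc1` gives 6.76%. All three numbers lie within the scatter of one another; compound 2 carries the smallest of them, but only by a margin the scatter swallows. Compound 4 `CS(=O)(=O)c1ccc(-c2cnc3[nH]cc(-c4nnc(-c5ccccc5)o4)c(=O)c3c2)cc1` differs from compound 2 in one place: hydrogen in place of methyl on an aromatic carbon. Within the data shown here, the one measured step on that ring, a number 0.1 percentage points higher from compound 2 to compound 3 (within the scatter), swapped a whole ring and moved nothing beyond the scatter, so it bears on the present change only loosely. Nothing here points to a move in this assay beyond the scatter, so compound 4 is expected to change little, a number 0.3 percentage points higher from compound 2 to compound 4 (within the scatter). The estimate for compound 4 is 7%, ranging from 1% to 14%.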

Compound 4, percent growth inhibition at one concentration: 8.17%
Estimate against measurement, compound 4: 1.2 percentage points below; low and high end bracket the measured number.
By their numbers in this assay, from the lowest: compounds 2, 3, 1 and 4 (each within the scatter of the next).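

In this assay, the methyl can be dropped from the 4-methylphenyl group with no shift beyond the scatter (a number 1.5 percentage points higher from compound 2 to compound 4 (within the scatter)). The plain phenyl also reads like the pyridin-4-yl ring (a number 1.4 percentage points higher from compound 3 to compound 4 (within the scatter)), so 4-methylphenyl, phenyl and pyridin-4-yl cannot be told apart here at this one concentration. No measurement shown accounts for these small differences. Still open, as far as these compounds go, is whether an amine or a carboxylic acid on this ring, para to the large group, would move the number beyond the scatter. A longer chain there is equally untested by these compounds.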